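The source may hold more compounds than are shown below. What is called first, only, known or untested is meant among the compounds shown, and "the series" means these compounds.

Measured compounds:
compound 1 `Cc1cccc(C)c1-c1cccc(COc2ccc(CCC(=O)O)cn2)c1` with 38 nM
compound 2 `Cc1cc(OCc2cccc(-c3c(C)cccc3C)c2)ncc1CCC(=O)O` with 130 nM
compound 3 `Cc1cc(CCC(=O)O)cnc1OCc1cccc(-c2c(C)cccc2C)c1` with 9100 nM

In a functional assay on CHO cells for agonist activity at Free fatty acid receptor 1 (Rattus norvegicus), read by calcium flux (a higher number here means that more compound is needed for the effect, a lower number that less compound is needed), compound 1 has the lowest number of the three; the nearest is reached by a 3.4-fold higher number from compound 1 to compound 2 (0.53 log units; beyond the scatter) and the furthest by a 240-fold higher number from compound 1 to compound 3 (2.38 log units; beyond the scatter). Both of these steps place a methyl on an aromatic carbon of the shared core.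

Compound 4 `COC(Cc1ccc(OCc2cccc(-c3c(C)cccc3C)c2)nc1)C(=O)O` differs from compound 1 by methoxy in place of hydrogen on a saturated chain carbon bound to a carbonyl carbon and a saturated chain carbon. This change sits on the chain, not on an aromatic carbon, so neither measured step bears on it directly; they only show that the chain region has not been probed. With nothing pointing either way, no step beyond the scatter is expected in this assay, and compound 4 is estimated at 40 nM (range 10 nM to 160 nM), that is a 1.1-fold higher number from compound 1 to compound 4 (0.02 log units; within the scatter).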

Compound 4, half-maximal effective concentration: > 10000 nM
Compound 4 gave a limit, no number; the forecaster's own chance of this, stated with the estimate: 3%; middle value at least 250-fold (2.39 log units) away from the limit.
By their numbers in this assay, from the lowest: compound 1; then compound 2; then compound 3. At a limit, above all of these: compound 4.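

In this assay, among these compounds, the chain proves far less forgiving than the earlier compounds could show, with an at least 260-fold higher number from compound 1 to compound 4 (2.42 log units; beyond the scatter) on a single change. Compound 4 stands at > 10000 nM in this reading, which is a limit of the assay and not a number. Among the compounds shown here, compound 2 and compound 3 changed only aromatic carbons, so this is the first sign that methoxy in place of hydrogen on this saturated chain carbon can cost this much.

From the compounds shown here alone, whether the loss is particular to methoxy stays open. A hydroxy group, a fluorine atom or an ethoxy group on the same carbon could still tell.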